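A few compounds are considered here, and "the series" means these few. Any claim that something is new, unique, unknown or untested is made for them only; others in the source may bear on it.

Of the compounds shown here, two sharing one core have been tested in a functional assay on A-375 cells (Homo sapiens) for antiproliferative activity; on this read-out higher numbers stand for weaker inhibition and lower numbers for stronger inhibition. Compound 1 `O=C(Nc1ccc(-c2cscn2)cc1)C1CCN(Cc2ccc(F)c(F)c2)C1` gives 10000 nM. Compound 2 `O=C(Nc1ccc(-c2ccccc2)cc1)C1CCCN(Cc2ccc(F)c(F)c2)C1` gives 2580 nM, the lowest of the two numbers and separated from compound 1 by more than the usual scatter. Compound 3 `O=C(Nc1ccc(-c2ccccn2)cc1)C1CCCN(Cc2ccc(F)c(F)c2)C1` differs from compound 2 in one place: pyridin-2-yl in place of phenyl on an aromatic carbon. Among the compounds with values here, no measured pair shows this exact change, so only a small shift is expected, either within the scatter or a modest weakening, with a step of a 1.4-fold higher number from compound 2 to compound 3 (0.13 log units; within the scatter) expected. Compound 3 is estimated at 3500 nM, with a range from 1200 nM to 10000 nM.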

Compound 3, half-maximal inhibitory concentration: 9000 nM
Compound 3: middle estimate off by 2.6-fold (0.41 log units), on the low side, and the stated range covers the measured number.
By their numbers in this assay, from the lowest: compound 2; then compounds 3 and 1 (each within the scatter of the next).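

In this assay, putting pyridin-2-yl in place of phenyl on an aromatic carbon, para to a large group, gives a 3.5-fold higher number from compound 2 to compound 3 (0.54 log units; beyond the scatter). This position is therefore sensitive to the change: exchanging one ring carbon for nitrogen, with the same number of heavy atoms, is enough for a modest weakening. No measurement shown here explains this step. Going by these compounds, it remains open whether pyridin-3-yl or pyridin-4-yl at this place would weaken inhibition as much, and whether a phenyl carrying an amine would match compound 2.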